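Swapping Dimethylamino for Chloro on a Cytotoxic Dienone

A few compounds are considered here, and "the series" means these few. Any claim that something is new, unique, unknown or untested is made for them only; others in the source may bear on it.

Of the compounds shown here, three sharing one dienone core have been measured in a functional assay on L1210 cells (Mus musculus) for cytotoxicity, with a stated time of 48 h; a higher number here means a weaker inhibitor, a lower number a stronger inhibitor. Compound 1 `COc1cc(/C=C2\CCC/C(=C\c3ccccc3[N+](=O)[O-])C2=O)cc(OC)c1OC` gives 1520 nM, compound 3 `O=C1/C(=C/c2ccccc2)CCC/C1=C\c1cccc([N+](=O)[O-])c1` gives 9440 nM, and compound 2 `CN(C)c1ccc(/C=C2\CCC/C(=C\c3ccccc3[N+](=O)[O-])C2=O)cc1` gives 164000 nM, the highest number of the three and beyond the scatter of both others, making compound 2 the weakest inhibitor shown. Compound 4 `O=C1/C(=C/c2ccc(Cl)cc2)CCC/C1=C\c1ccccc1[N+](=O)[O-]` is not yet measured; it differs from compound 2 by chloro in place of dimethylamino on an aromatic carbon. Compound 3, whose second ring carries no substituent at all, sits far below compound 2, and a chloro group seems a smaller departure from that bare ring than dimethylamino is. A large step downward is expected: a 33-fold lower number from compound 2 to compound 4 (1.52 log units; beyond the scatter). Compound 4 is estimated at 5000 nM, ranging from 1500 nM to 20000 nM.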

Compound 4, half-maximal inhibitory concentration: 9380 nM
Beside the measured number, compound 4's estimate is 1.9-fold (0.27 log units) below it; the measured number falls inside the stated range.
By their numbers in this assay, from the lowest: compound 1; then compounds 4 and 3 (each within the scatter of the next); then compound 2.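

Going by these compounds alone, this is the first pair here that differs in one place only: in this assay, chloro in place of dimethylamino on the aromatic carbon gives a 17-fold lower number from compound 2 to compound 4 (1.24 log units; beyond the scatter) and nothing else in the structure changes. The group on this one carbon can therefore shift the number well beyond the scatter, so this position is not indifferent to what sits on it. Open, from the compounds shown here alone, is whether a methoxy group, a fluoro group or a primary amine on this carbon would track chloro or dimethylamino. The data shown offer no measured reason for the size of this step.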